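The source may report more compounds than this note shows. Statements on the series, on what has been measured and on what is new or still open speak of the compounds shown alone.

Measured in an ADME assay for metabolic stability, in phosphate buffer, at pH 7.3; a lower number here means that the compound disappears faster, a higher number that the compound lasts longer:
- compound 1 `Cc1cccc2c1OP(=O)(OCC1CCC(n3cnc4c(O)ncnc43)O1)OC2`: 44.5 h
- compound 2 `Nc1ncnc2c1ncn2C1CCC(COP2(=O)OCc3ccccc3O2)O1`: 17 h

Of these two numbers, compound 1 stands highest at 44.5 h. Compound 2 is the nearest at 17 h, and the gap between them lies beyond the usual scatter of repeated measurements. Within the data shown here, the series so far holds no measured step that isolates a single structural change, so the size of any such change in this assay remains unknown.

The next compound, compound 3 `Cc1cccc2c1OP(=O)(OCC1CC(O)C(n3cnc4c(O)ncnc43)O1)OC2`, has not yet been measured. It departs from compound 1 by hydroxy in place of hydrogen on a saturated ring carbon. No step beyond the scatter is expected in this assay, with only a slight lean towards a lower number, and the anchor for this expectation is compound 1 at 44.5 h. The expected change is a 1.2-fold lower number from compound 1 to compound 3 (0.07 log units; within the scatter). For compound 3 the estimate is 38 h, with an expected range of 20 h to 65 h.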

Compound 3, half-life: 29.7 h
Compound 3: the middle estimate sits 1.3-fold (0.11 log units) above what was measured, and the stated range covers the measured number.
By their numbers in this assay, from the lowest: compounds 2, 3 and 1 (each within the scatter of the next, the first and the last beyond it).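

In this assay, the series now has its first step that isolates one change: hydroxy in place of hydrogen on a saturated ring carbon of the five-membered non-aromatic ring with 1 oxygen gives a 1.5-fold lower number from compound 1 to compound 3 (0.18 log units; within the scatter). Among these compounds, at this position, two ring bonds from the ring oxygen and next to the ring atom that bears a large group, the added hydroxy therefore produces no step that can be told apart from repeat measurements, and compound 3 reads as level with compound 1. This rests on a single pair on a single core, and nothing measured accounts for the size of the step.

Still open, from the compounds shown here alone, is whether other groups on the same ring carbon, such as an amine, a methoxy group, a fluorine atom or a longer chain such as hydroxymethyl, would also stay within the scatter or would open a real gap from compound 1. Also open, going by these compounds, is whether a hydroxy elsewhere on this ring, or the same hydroxy on the core of compound 2, would give a step of similar size.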